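A few compounds are considered here, and "the series" means these few. Any claim that something is new, unique, unknown or untested is made for them only; others in the source may bear on it.

Measured in an assay on CHO cells for binding affinity to melanin-concentrating hormone receptor 1 (Homo sapiens); a lower number here means a stronger inhibitor, a higher number a weaker inhibitor:
compound 1 `CN1CCN(CCCN(C(=O)Nc2ccc(F)c(Cl)c2)C2CCc3cc(C#N)ccc3C2)CC1` — 340 nM
compound 2 `COc1ccc2c(c1)CCC(N(CCCN1CCN(C)CC1)C(=O)Nc1ccc(F)c(Cl)c1)C2` — 190 nM
compound 3 `CN1CCN(CCCN(C(=O)Nc2ccc(F)c(Cl)c2)C2CCc3ccc(S(C)(=O)=O)cc3C2)CC1` — 1300 nM

Compound 3 stands highest of the three numbers, and its gap to compound 1 and to compound 2 lies beyond the scatter. Compound 4 `CN1CCN(CCCN(C(=O)Nc2ccc(F)c(Cl)c2)C2CCc3ccc(N)cc3C2)CC1` differs from compound 3 by amino in place of methylsulfonyl on an aromatic carbon. Among the measured compounds shown here, the one measured step at an aromatic carbon of this core, a 1.8-fold lower number from compound 1 to compound 2 (0.25 log units; within the scatter), stayed within the scatter; no measured step covers amino. Since compound 3 carries the highest number and compound 1 and compound 2, with other substituents at this part of the core, both stand below it, a lower number is expected for compound 4, with a 3.3-fold lower number from compound 3 to compound 4 (0.51 log units; beyond the scatter) as the estimated step. The estimate for compound 4 is 400 nM, in the range 150 nM to 1100 nM.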

Compound 4, inhibition constant: 260 nM
The estimate for compound 4 lay 1.5-fold (0.19 log units) above the measured number; the range from low to high includes it.
By their numbers in this assay, from the lowest: compounds 2, 4 and 1 (each within the scatter of the next); then compound 3.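

In this assay, among the compounds shown here, the change at this aromatic carbon gives a 5.0-fold lower number from compound 3 to compound 4 (0.70 log units; beyond the scatter), the first step beyond the scatter, whereas a 1.8-fold lower number from compound 1 to compound 2 (0.25 log units; within the scatter) did not separate methoxy from cyano. Compound 4 groups with compound 1 and compound 2, each within the scatter of the next, leaving compound 3 alone at the high end. No available data give a cause for this step.

Open, on these data alone, is whether a dimethylamino group, an acetamide or a hydroxyl at this carbon would stay with compound 4 or move towards compound 3.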